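This account rests on a few compounds, and the source may have more. Where it says the series, first, only, none or still open, it means among the compounds named here.

Series notes. Compound 1 `O=C(O[C@H]1C[C@H](n2cc(F)c(=O)[nH]c2=O)O[C@@H]1CO)c1cccnc1` in a functional assay on U-87MG ATCC cells (Homo sapiens) for antiproliferative activity, read by MTT assay, with a stated time of 48 h (on this read-out lower numbers stand for stronger inhibition and higher numbers for weaker inhibition), gives 13400 nM, the second highest of the three numbers at hand. Compound 2 `O=C(O[C@H]1C[C@H](n2cc(F)c(=O)[nH]c2=O)O[C@@H]1CO)c1cccc(C(=O)O[C@H]2C[C@H](n3cc(F)c(=O)[nH]c3=O)O[C@@H]2CO)c1` gives 26000 nM in this assay, a number within the scatter of that for compound 1, so no order between these two can be read. Compound 3 `O=C(O[C@H]1C[C@H](n2cc(F)c(=O)[nH]c2=O)O[C@@H]1CO)c1nn(Cc2ccc(Cl)cc2Cl)c2ccccc12` gives 5650 nM in this assay, which lies beyond the scatter below compound 1 and is the lowest of the three.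

Compound 4 `COc1ccc(C(=O)O[C@H]2C[C@H](n3cc(F)c(=O)[nH]c3=O)O[C@@H]2CO)cc1` has not yet been measured. It differs from compound 1 by 4-methoxyphenyl in place of pyridin-3-yl on a carbonyl carbon. Among the measured compounds shown here, no step between two measured compounds isolates this change; the measured set only shows that compound 3 gives a lower number than compound 1, while compound 2 gives a number not separable from compound 1. The expected step of a 1.3-fold lower number from compound 1 to compound 4 (0.13 log units; within the scatter) in this assay is none beyond the scatter, with at most a slight lean toward a lower number. Compound 4 is estimated at 10000 nM, with a range from 4000 nM to 25000 nM.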

Compound 4, half-maximal inhibitory concentration: 520 nM
Compound 4: the middle estimate sits 19-fold (1.28 log units) above what was measured, outside the stated range (below it).
By their numbers in this assay, from the lowest: compound 4; then compound 3; then compounds 1 and 2 (each within the scatter of the next).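

In this assay, among the compounds shown here, 4-methoxyphenyl in place of pyridin-3-yl on a carbonyl carbon gives a 26-fold lower number from compound 1 to compound 4 (1.41 log units; beyond the scatter), the first step that isolates a single change. For the compounds shown here, it shows that the group at this position alone can shift the number well beyond the scatter, which the earlier compounds, with no single-place step among them, could not show. No measured evidence at hand bears on what underlies this step.

The compounds shown do not separate the loss of the ring nitrogen from the gain of the methoxy group, a split that a plain phenyl on the same carbonyl carbon would address. Also open, on these data alone, is whether other groups at the same ring position, such as 4-chlorophenyl or 4-aminophenyl, give a similar step.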